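The compounds below may be only part of what the source reports. "The series", "measured", "known", "first", "only" and "open" are said of these compounds alone.

In a functional assay on A549 cells (Homo sapiens) for cytotoxicity, read by MTT assay, with a stated time of 68 h (on this read-out higher numbers stand for weaker inhibition and lower numbers for stronger inhibition), compound 1 (`CC(C)Oc1ccc(-c2cc(NC(=O)C(Cl)Cl)cc(-c3ccc(OC(C)C)cc3)c2)cc1`) gives 3820 nM and compound 2 (`Cc1ccc(-c2cccc(NC(=O)C(Cl)Cl)c2)cc1`) gives 8300 nM while compound 3 (`O=C(Nc1cccc(-c2ccc(F)cc2)c1)C(Cl)Cl`) gives 7840 nM on the same read-out. Compound 3 thus cannot be told apart from compound 2, and its number is higher than that of compound 1, by a margin just beyond the scatter.

The next compound is compound 4 (`O=C(Nc1cccc(-c2ccc(Cl)cc2)c1)C(Cl)Cl`), which carries chloro in place of fluoro on an aromatic carbon, para to a large group (chloro in place of fluoro on an aromatic carbon). For the measured compounds named here, only one measured step bears on this place. It is a 1.1-fold lower number from compound 2 to compound 3 (0.02 log units; within the scatter) for fluoro in place of methyl on an aromatic carbon, and it stays within the scatter. Two different groups at this place have therefore left the number in this assay unmoved, so no step beyond the scatter is expected here. The estimated change is a 1.1-fold lower number from compound 3 to compound 4 (0.05 log units; within the scatter) and would be a small drift at most. For compound 4 the expected value is 7000 nM with an estimated range from 3800 nM to 12000 nM.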

Compound 4, half-maximal inhibitory concentration: 36200 nM
Beside the measured number, compound 4's estimate is 5.2-fold (0.71 log units) below it; the whole stated range lies below it.
By their numbers in this assay, from the lowest: compound 1; then compounds 3 and 2 (each within the scatter of the next); then compound 4.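

In this assay this place on the aromatic carbon, para to a large group, proves sensitive to what it carries: chloro in place of fluoro gives a 4.6-fold higher number from compound 3 to compound 4 (0.66 log units; beyond the scatter), and chloro in place of methyl gives a 4.4-fold higher number from compound 2 to compound 4 (0.64 log units; beyond the scatter). Methyl and fluoro had stayed within the scatter of each other, so chloro is the first of the three groups here to separate from the others, and it does so towards weaker inhibition. Nothing available accounts for this separation.

The compounds shown leave open whether the loss is confined to chloro or would also appear with bromo, methoxy or an amine at this place. They also leave open whether chloro in place of fluoro would have the same effect on the core of compound 1.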